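The source may hold more compounds than are shown below. What is called first, only, known or untested is meant among the compounds shown, and "the series" means these compounds.

Measured so far:

Compound 1 `COC(=O)[C@@]1(C)CCC=C2[C@@H]1CC[C@@H](C)[C@]2(C)Cc1c[nH]c2ccc(Br)cc12`, giving 16000 nM in a functional assay on T47D cells (Homo sapiens) for inhibition, read by sulforhodamine B assay, with a stated time of 48 h; on this read-out higher numbers stand for weaker inhibition of growth and lower numbers for stronger inhibition of growth.
Compound 2 `COC(=O)[C@@]1(C)CCC=C2[C@@H]1CC[C@@H](C)[C@]2(C)Cc1c(C)[nH]c2ccc(Br)cc12`, giving 16000 nM in this assay.
Compound 3 `COC(=O)[C@@]1(C)CC[C@@H]2C3=C1CC[C@@H](C)[C@]3(C)C[C@@H]1c3ccccc3N[C@H]21`, giving 35000 nM in this assay.

The first pair differs in one place: methyl in place of hydrogen on an aromatic carbon. This change brought no change at the digits printed from compound 1 to compound 2 (within the scatter), so adding the methyl there left the growth inhibition where it was. Compound 3 is built on a different core; the difference between the two cores is not broken down here. Its number in this assay is the highest of the three, and the gap to compound 1 and to compound 2 lies beyond the usual scatter, so compound 3 inhibits growth more weakly than either.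

Compound 4 `COC(=O)[C@@]1(C)CC[C@@H]2C3=C1CC[C@@H](C)[C@]3(C)C[C@@H]1c3cc(C)ccc3N[C@H]21` has not been measured. It differs from compound 3 in one place: methyl in place of hydrogen on an aromatic carbon. This is the same kind of change as that from compound 1 to compound 2, but not the same: in compound 2 the methyl sits on a five-membered aromatic ring with 1 nitrogen, next to the ring nitrogen and next to the ring atom that bears a large group, whereas in compound 4 it sits on a six-membered aromatic ring of carbon only, meta to a fused ring and para to a fused ring, within a fused system of five rings.

Going by the values given here, because the one measured example of this kind of change gave no change at the digits printed from compound 1 to compound 2 (within the scatter), the expectation for compound 4 in this assay is a step of about no change at the digits printed from compound 3 to compound 4 (within the scatter), resting on a single precedent on a different core and at a different place. Compound 4 is therefore estimated at 35000 nM, with a plausible range from 15000 nM to 80000 nM.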

Compound 4, concentration for 50% growth inhibition: 23000 nM
Compound 4: middle estimate off by 1.5-fold (0.18 log units), on the high side, within the range that was stated.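

In this assay, putting a methyl on the six-membered aromatic ring of compound 3 gives a 1.5-fold lower number from compound 3 to compound 4 (0.18 log units; within the scatter), so compound 3 and compound 4 cannot be told apart by this measurement. Set beside the earlier methyl step, the result on the second core agrees with the first: the same change on two cores in this assay, no change at the digits printed (within the scatter) from compound 1 to compound 2 and a 1.5-fold lower number (0.18 log units; within the scatter) from compound 3 to compound 4, 1.5-fold (0.18 log units) apart, within the scatter of two such steps This shows that, in these two pairs, replacing a hydrogen on an aromatic carbon with a methyl left growth inhibition within the scatter on both cores, but it does not show that the change will behave the same way on any other core, and because the methyl sits at a different place on each core, the effects of core and place cannot be separated; nor is it a demanding test of transfer, since neither step is large enough to rise beyond the scatter.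

Still open, as far as these compounds go, is whether an ethyl, a longer chain or an amine on the same aromatic carbon, or a methyl on another carbon of that ring, would move the number beyond the scatter. From the compounds shown here alone, the methyl ester is also the same in all four compounds, so what a carboxylic acid in its place would do remains unknown.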